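Methoxy for fluoro on a second core

The source may report more compounds than this note shows. Statements on the series, on what has been measured and on what is new or still open speak of the compounds shown alone.

In a functional assay on the whole organism (strain Wistar albino) for inhibition, with Rattus norvegicus as the target, read by paw edema, with stated times of 1 h and 3 h, at a dose of 0.32 mmol/kg by the intraperitoneal route (on this read-out lower numbers stand for less inhibition and higher numbers for more inhibition at the one dose given (going by the name of the read-out)), compound 1 `Cc1ccc(-c2nn(-c3ccc(S(N)(=O)=O)cc3)cc2C(CC(=O)c2ccc(Cl)cc2)C(=O)c2ccc(F)cc2)cc1` gives 56.2% and compound 2 `COc1ccc(C(=O)C(CC(=O)c2ccc(Cl)cc2)c2cn(-c3ccc(S(N)(=O)=O)cc3)nc2-c2ccc(C)cc2)cc1` gives 61.1%. The two differ by methoxy in place of fluoro on an aromatic carbon, and the step amounts to a number 4.9 percentage points higher from compound 1 to compound 2 (within the scatter).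

Compound 3 `Cc1ccc(-c2nn(-c3ccc(Cl)cc3)cc2-c2cc(-c3ccc(Cl)cc3)[nH]c2-c2ccc(F)cc2)cc1` is built on a different core; how that core differs from the core of compound 1 is not broken down here. In this assay compound 3 gives 21%, the lowest of the three numbers and beyond the scatter from both compound 1 and compound 2.

Compound 4 `COc1ccc(-c2[nH]c(-c3ccc(Cl)cc3)cc2-c2cn(-c3ccc(Cl)cc3)nc2-c2ccc(C)cc2)cc1` has not been measured. It differs from compound 3 by methoxy in place of fluoro on an aromatic carbon. The place of the change reads word for word as it does between compound 1 and compound 2, so it is the same change, although read one bond further out it is described only as 4-fluorophenyl to 4-methoxyphenyl, while between compound 1 and compound 2 it also reads (4-fluorophenyl)carbonyl to (4-methoxyphenyl)carbonyl.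

The step from compound 3 to compound 4 is expected to be about a number 4 percentage points higher from compound 3 to compound 4 (within the scatter), a change of the same small size as the earlier one, because the step from compound 1 to compound 2 was a number 4.9 percentage points higher from compound 1 to compound 2 (within the scatter). Compound 4 is therefore estimated to give about 25% in this assay, with a range from 12% to 40%.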

Compound 4, a percentage reported as inhibition, in the whole organism at one dose (the size of the read-out at that dose, not a potency): 21.3%
For compound 4 the middle estimate is 3.7 percentage points above the measured one; low and high end bracket the measured number.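

On the second core, the change from 4-fluorophenyl to 4-methoxyphenyl comes to a number 0.3 percentage points higher from compound 3 to compound 4 (within the scatter) in this assay. Set beside the same change on the first core, the two steps cannot be told apart, so within this small set the change carries over from one core to the other as a small step on both: the same change on two cores in this assay, a number 4.9 percentage points higher (within the scatter) from compound 1 to compound 2 and a number 0.3 percentage points higher (within the scatter) from compound 3 to compound 4, 4.6 percentage points apart, within the scatter of two such steps This does not show that methoxy improves on fluoro on either core, since neither step rises above the scatter, and with only two pairs, read at one dose in one assay, it offers no general rule for other cores, no measure of potency and no explanation of why the steps are small.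

The compounds shown leave open whether a different group in the same place, such as an amine, a carboxylic acid or a longer chain like butoxy, would give a step beyond the scatter on either core. They also leave open whether such a step, if one exists, would be the same size on both cores, which is the stricter test of carrying a change across that two small steps cannot supply.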